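The source may report more compounds than this note shows. Statements on the series, on what has been measured and on what is new or still open speak of the compounds shown alone.

Of the compounds shown here, three sharing one core have been measured in a functional assay on K562 cells (Homo sapiens) for antiproliferative activity; a higher number here means a weaker inhibitor of growth, a lower number a stronger inhibitor of growth. Compound 1 `CC(C)(C)C(=O)OCC1(CO)C/C(=C\CCCCCCCCCCCO)C(=O)O1` gives 1.09 ug/mL, compound 2 `CC(=O)OCCCCCCCCCCCCCCC/C=C1\CC(CO)(COC(=O)C(C)(C)C)OC1=O` gives 0.959 ug/mL, and compound 3 `CCCCCCCCC(O)CCCCCC/C=C1\CC(CO)(COC(=O)C(C)(C)C)OC1=O` gives 7.3 ug/mL. Compound 3 therefore stands with the highest number of the three and is the weakest inhibitor of growth, with compound 1 nearest and compound 2 furthest. Compound 4 `CC(C)(C)C(=O)OCC1(CO)C/C(=C\CCCCCCCCCCCCCCC=O)C(=O)O1` is not yet measured; it differs from compound 3 in one place: 8-formyloctyl in place of 1-hydroxynonyl on a saturated chain carbon, six bonds along the chain from a double-bonded chain carbon.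

Among the compounds with values here, two measured steps bear on this. a 1.1-fold lower number from compound 1 to compound 2 (0.06 log units; within the scatter): exchanging a hydroxy for a 4-acetoxybutyl changed nothing beyond the scatter. a 6.7-fold higher number from compound 1 to compound 3 (0.83 log units; beyond the scatter): putting 1-hydroxynonyl in place of 5-hydroxypentyl weakened growth inhibition modestly. Within the data shown here, the change to compound 4 removes that 1-hydroxynonyl again and brings in 8-formyloctyl, so it undoes the only alteration that set compound 3 apart from compound 1. A step back in the reverse direction, towards the numbers of compound 1 and compound 2, is thus the most reasonable expectation, although an aldehyde was not among the measured groups, which widens the uncertainty. Compound 4 is therefore estimated at 1.5 ug/mL, with a range from 0.6 ug/mL to 4.5 ug/mL, which means an expected 4.9-fold lower number from compound 3 to compound 4 (0.69 log units; beyond the scatter).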

Compound 4, concentration for 50% growth inhibition: 5.11 ug/mL
Estimate against measurement, compound 4: 3.4-fold (0.53 log units) below, outside the stated range (above it).
By their numbers in this assay, from the lowest: compounds 2 and 1 (each within the scatter of the next); then compounds 4 and 3 (each within the scatter of the next).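

In this assay, the step from 1-hydroxynonyl to 8-formyloctyl, on a saturated chain carbon six bonds along the chain from a double-bonded chain carbon, gives a 1.4-fold lower number from compound 3 to compound 4 (0.15 log units; within the scatter), so this change leaves compound 3 and compound 4 level, and taking away the 1-hydroxynonyl group does not by itself bring back the numbers of the other two compounds. The formyl group instead keeps compound 4 apart from both of them, with a 5.3-fold higher number from compound 2 to compound 4 (0.73 log units; beyond the scatter) and a 4.7-fold higher number from compound 1 to compound 4 (0.67 log units; beyond the scatter), which splits these four compounds into two pairs: compound 1 with compound 2, and compound 3 with compound 4. Nothing available here explains why the formyl compound falls with the weaker pair.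

The compounds shown leave open whether the formyl group itself or the chain carrying it sets this level, since compound 1 and compound 4 differ in both. Going by these compounds, how a carboxylic acid or an amine in the same place would compare, or a shorter chain ending in formyl, also remains open.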